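The source may report more compounds than this note shows. Statements on the series, on what has been measured and on what is new or still open speak of the compounds shown alone.

The study opens with two measured compounds. Compound 1 `COc1ccccc1N1CCN(CCCOc2ccccc2C(=O)N(C)C)CC1` in a functional assay for antagonist activity at Alpha-1A adrenergic receptor (Oryctolagus cuniculus) (a higher number here means weaker binding, a lower number tighter binding), gives 3.98 nM. Compound 2 `CN(C)C(=O)c1cnc2c(Cl)cccc2c1NCCCN1CCN(c2ccccc2OCC(F)(F)F)CC1` in this assay gives 0.794 nM, the lower of the two numbers; compound 1 sits at the higher one, and the gap between them lies beyond the scatter. Compound 3 `CN(C)C(=O)c1cnc2ccccc2c1NCCCN1CCN(c2ccccc2OCC(F)(F)F)CC1` has not yet been measured in this assay. It differs from compound 2 in one place: hydrogen in place of chloro on an aromatic carbon of a six-membered ring that is part of a fused system of two rings. Going by the values given here, no step between two measured compounds shows what such a change does here, so the expectation rests on compound 2 and its 0.794 nM alone. The expected step is a 1.9-fold higher number from compound 2 to compound 3 (0.28 log units; within the scatter), a small rise in the number that may not reach beyond the scatter, since nothing in the measured pair speaks for a large loss. Compound 3 is therefore estimated to give 1.5 nM in this assay, with a range from 0.5 nM to 5 nM.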

Compound 3, dissociation constant: 3.98 nM
The estimate for compound 3 lay 2.7-fold (0.42 log units) below the measured number; low and high end bracket the measured number.
By their numbers in this assay, from the lowest: compound 2; then compounds 1 and 3 (each within the scatter of the next).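

In this assay, going by these compounds alone, this pair gives the first direct reading of the position: with hydrogen in place of chloro on an aromatic carbon of the six-membered aromatic ring of carbon only, the result is a 5.0-fold higher number from compound 2 to compound 3 (0.70 log units; beyond the scatter) and the step lies beyond the scatter. The chloro therefore matters at this position, since one heavy atom, with no ring, no net charge and no hydrogen-bond donors or acceptors, separates two compounds that are otherwise the same. No measurement bearing on the reason for this step is available.

From the compounds shown here alone, only chloro and hydrogen have been compared on this carbon, so it remains open whether a fluoro, a bromo or a methyl group there would keep the number close to that of compound 2 or move it further from that of compound 3. Going by these compounds, it is also open whether the chloro would count for as much if a longer chain replaced the present one, as this single step comes from one pair with everything else held the same.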